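From tert-Butyl to 4-Fluorophenyl: Expected Cytotoxicity of Compound 4

This account rests on a few compounds, and the source may have more. Where it says the series, first, only, none or still open, it means among the compounds named here.

Compound 1, `Cc1c(Cc2ccccc2)c(=O)oc2cc(OCC(O)CNc3nccs3)ccc12`: 93000 nM
Compound 2, `Cc1c(Cc2ccc(C(C)(C)C)cc2)c(=O)oc2cc(OCC(O)CN3CCC(C(N)=O)CC3)ccc12`: 14700 nM
Compound 3, `Cc1c(Cc2cccc(F)c2)c(=O)oc2cc(OCC(O)CN3CCC(C(N)=O)CC3)ccc12`: 53300 nM

All three numbers come from an ADME assay on A549 cells (Homo sapiens) for cytotoxicity, read by CellTiter-Glo; on this read-out higher numbers stand for lower toxicity in this test and lower numbers for higher toxicity in this test. Compound 2 stands at the lowest of the three numbers, so it is the most toxic here; compound 1 gives the highest. Within the data shown here, the one single-point step among them is a 3.6-fold higher number from compound 2 to compound 3 (0.56 log units; beyond the scatter), which lies beyond the scatter.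

Compound 4, `Cc1c(Cc2ccc(-c3ccc(F)cc3)cc2)c(=O)oc2cc(OCC(O)CN3CCC(C(N)=O)CC3)ccc12`, differs from compound 2 in one place: 4-fluorophenyl in place of tert-butyl on an aromatic carbon. Among the measured compounds shown here, the step of a 3.6-fold higher number from compound 2 to compound 3 (0.56 log units; beyond the scatter) touches the same part of the molecule but is a different exchange, so it gives only a weak guide; no measured pair matches this change. A modest step at most, in either direction, is expected in this assay. Compound 4 is expected to give 12000 nM, with a range from 4000 nM to 40000 nM. That estimate corresponds to a 1.2-fold lower number from compound 2 to compound 4 (0.09 log units; within the scatter).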

Compound 4, half-maximal cytotoxic concentration: 19300 nM
The estimate for compound 4 lay 1.6-fold (0.21 log units) below the measured number, within the range that was stated.
By their numbers in this assay, from the lowest: compounds 2 and 4 (each within the scatter of the next); then compounds 3 and 1 (each within the scatter of the next).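

Exchanging tert-butyl for 4-fluorophenyl on this aromatic carbon gives a 1.3-fold higher number from compound 2 to compound 4 (0.12 log units; within the scatter) in this assay, so this read-out does not separate the two groups. At this position, then, a group with seven heavy atoms and an aromatic ring gives a number within the scatter of the number given by the four-carbon tert-butyl. No supporting measurement is available to explain this result.

Going by these compounds, whether an amine or a carboxylic acid on this aromatic carbon would also stay within the scatter of compound 2 remains open. It is also unclear whether the fluorine of the 4-fluorophenyl group contributes anything to the number.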